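Series notes: aryl exchange on the fused core

This account rests on a few compounds, and the source may have more. Where it says the series, first, only, none or still open, it means among the compounds named here.

Measured so far in an assay on HEK-293T cells for displacement of a labelled ligand from corticotropin-releasing factor receptor 1 (Homo sapiens), read by scintillation counting, with a stated time of 2 h; on this read-out lower numbers stand for stronger inhibition and higher numbers for weaker inhibition:
compound 1, `CCCCN(CC)c1cc(C)nc2c1NC(=O)CN2c1ccc(C(C)(C)C)cc1Br`, 4.2 nM
compound 2, `CCCCN(CC)c1cc(C)nc2c1NC(=O)CN2c1ccc(C(C)C)cc1Br`, 2.4 nM
compound 3, `CCCCN(CC)c1cc(C)nc2c1NC(=O)CN2c1ccc(Cl)cc1Br`, 2.5 nM

Compound 3 holds the second highest of the three numbers; the nearest is compound 2 (a 1.0-fold higher number from compound 2 to compound 3 (0.02 log units; within the scatter)), the furthest compound 1 (a 1.7-fold lower number from compound 1 to compound 3 (0.23 log units; within the scatter)). Both steps lie within the scatter, so the three compounds are not separated on this read-out.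

Compound 4, `CCCCN(CC)c1cc(C)nc2c1NC(=O)CN2c1ccc(I)cc1C`, has not yet been measured. Its change from compound 3 is 4-iodo-2-methylphenyl in place of 2-bromo-4-chlorophenyl on a nitrogen on an aromatic ring in a ring. Among the measured compounds shown here, two measured steps bear on this partly: chloro in place of tert-butyl (a 1.7-fold lower number from compound 1 to compound 3 (0.23 log units; within the scatter)) and chloro in place of isopropyl (a 1.0-fold higher number from compound 2 to compound 3 (0.02 log units; within the scatter)), both on an aromatic carbon of the same ring, both within the scatter. For the measured compounds named here, no measured step covers an exchange of bromo for methyl, nor of chloro for iodo, so that part of the change is unsupported by data. With the halogen and alkyl exchanges shown so far all within the scatter, compound 4 is expected to give a number close to compound 3, as an estimated step of a 1.4-fold higher number from compound 3 to compound 4 (0.15 log units; within the scatter). Compound 4 is therefore estimated at 3.5 nM, in the range 1 nM to 12 nM.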

Compound 4, inhibition constant: 3.4 nM
For compound 4 the middle estimate is 1.0-fold (0.01 log units) above the measured one; the range from low to high includes it.
By their numbers in this assay, from the lowest: compounds 2, 3, 4 and 1 (each within the scatter of the next).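

Compounds 1, 2 and 3 all keep the bromo group and differ only in the other substituent on the aryl ring, whereas compound 4 exchanges the whole aryl group on the ring nitrogen, with 4-iodo-2-methylphenyl in place of 2-bromo-4-chlorophenyl. In this assay this exchange gives a 1.4-fold higher number from compound 3 to compound 4 (0.13 log units; within the scatter), so bromo is not required for a value in the same range as the other three compounds. No measurement on the origin of this outcome is available.

With both substituents exchanged in one step, the share of each exchange cannot be separated, and all four compounds remain unresolved on this read-out. Going by these compounds, it also remains open whether a group of another kind on this aryl ring, such as an amine or a carboxylic acid, would give a step beyond the scatter.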